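The source may hold more compounds than are shown below. What is called first, only, known or untested is meant among the compounds shown, and "the series" means these compounds.

In a functional assay on SK-MEL-28 cells (Homo sapiens) for cytotoxicity, read by CCK-8 assay, with a stated time of 24 h (a higher number here means a weaker inhibitor, a lower number a stronger inhibitor), compound 1 `COc1ccccc1Oc1c(N)nc(Cc2ccccc2)nc1OCCO` gives 14000 nM and compound 2 `COc1ccccc1Oc1c(N)nc(-c2cccc(F)c2)nc1OCCO` gives 3210 nM, the lower of the two numbers. Compound 3 `COc1ccccc1Oc1c(N)nc(-c2ccc(F)cc2)nc1OCCO` has 4-fluorophenyl in place of 3-fluorophenyl on an aromatic carbon. For the measured compounds named here, the only measured step, a 4.4-fold lower number from compound 1 to compound 2 (0.64 log units; beyond the scatter), replaced benzyl with 3-fluorophenyl on that same carbon. It shows that this group can matter, but it does not test a change in where the fluorine sits. No step beyond the scatter is therefore expected. The estimated step is a 1.1-fold higher number from compound 2 to compound 3 (0.04 log units; within the scatter). For compound 3 the expected value is 3500 nM, with an estimated range of 1500 nM to 8000 nM.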

Compound 3, half-maximal inhibitory concentration: 20100 nM
Compound 3: middle estimate off by 5.7-fold (0.76 log units), on the low side; the whole stated range lies below it.
By their numbers in this assay, from the lowest: compound 2; then compounds 1 and 3 (each within the scatter of the next).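

Moving the fluorine alone matters at this carbon between the two ring nitrogen atoms: in this assay the change gives a 6.3-fold higher number from compound 2 to compound 3 (0.80 log units; beyond the scatter) and so separates two groups with the same atoms. The other step, a 1.4-fold higher number from compound 1 to compound 3 (0.16 log units; within the scatter), leaves 4-fluorophenyl and benzyl indistinguishable here, so a fluorophenyl group in place of benzyl does not by itself give a lower number; of the two, only 3-fluorophenyl does. No measured evidence explains this difference. As far as these compounds go, whether an unsubstituted phenyl, or a chlorine or methoxy group in place of the fluorine, would resemble compound 2 or compound 3 remains open.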